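Swapping a chloro for a cyclohexyl on an exchanger inhibitor

A few compounds are considered here, and "the series" means these few. Any claim that something is new, unique, unknown or untested is made for them only; others in the source may bear on it.

Compound 1 `Cc1cc(Cl)c(S(C)(=O)=O)cc1C(=O)N=C(N)N` is the reference point here. In a functional assay for inhibition of sodium/hydrogen exchanger (Oryctolagus cuniculus) (on this read-out lower numbers stand for stronger inhibition and higher numbers for weaker inhibition), compound 1 gives 25 nM, the lowest of the three numbers at hand. Compound 2 `CS(=O)(=O)c1cc(C(=O)N=C(N)N)c(Cl)cc1Cl` gives 140 nM, and compound 3 `Cc1c(C(=O)N=C(N)N)cc(S(C)(=O)=O)c(Cl)c1C` gives 58 nM. Both sit above compound 1: a 5.6-fold higher number from compound 1 to compound 2 (0.75 log units; beyond the scatter), and a 2.3-fold higher number from compound 1 to compound 3 (0.37 log units; beyond the scatter). Each of these steps is modest, and each alters a different part of the ring than the one changed next.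

Compound 4 `Cc1cc(C2CCCCC2)c(S(C)(=O)=O)cc1C(=O)N=C(N)N` differs from compound 1 in one place: cyclohexyl in place of chloro on an aromatic carbon. Within the data shown here, no measured step touches the chloro, so nothing here shows directly what a much larger group at that position does. The two measured changes elsewhere on the ring each raised the number beyond the scatter, so a step in the same direction seems the most reasonable expectation, plausibly somewhat larger given the size of the group entering.

For compound 4 the expected result is 90 nM, within a range of 25 nM to 350 nM, which corresponds to an estimated step of a 3.6-fold higher number from compound 1 to compound 4 (0.56 log units; beyond the scatter).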

Compound 4, half-maximal inhibitory concentration: 22 nM
The estimate for compound 4 lay 4.1-fold (0.61 log units) above the measured number, and the stated range ends above it.
By their numbers in this assay, from the lowest: compounds 4 and 1 (each within the scatter of the next); then compound 3; then compound 2.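

In this assay, cyclohexyl in place of chloro brings 6 heavy atoms and a non-aromatic ring where a single chlorine stood, yet the result is a 1.1-fold lower number from compound 1 to compound 4 (0.06 log units; within the scatter) and the two compounds cannot be told apart on this read-out. Among these compounds, this is the first direct look at the place ortho to the methylsulfonyl group, and it shows that a far larger carbon group can sit there without moving the number beyond the usual scatter, unlike the two earlier changes elsewhere on the ring. Nothing available here gives a measured reason for this outcome.

On these data alone, whether an amine, a carboxylic acid or a longer carbon chain at this place would give a similar number remains open. Also open, as far as these compounds go, is whether a smaller ring, such as cyclopropyl, would fit the same picture.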